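This account rests on a few compounds, and the source may have more. Where it says the series, first, only, none or still open, it means among the compounds named here.

Measured compounds in the series:

- compound 1, `NCc1cc(C(N)=O)ccc1CN(Cc1nc2ccccc2[nH]1)C1CCCc2cccnc21`: 15 nM
- compound 2, `NCc1cscc1N(Cc1nc2ccccc2[nH]1)C1CCCc2cccnc21`: 13 nM

Both numbers come from a functional assay on CEM-CCRF cells for antagonist activity at C-X-C chemokine receptor type 4 (Homo sapiens), read by calcium flux; on this read-out lower numbers stand for stronger inhibition and higher numbers for weaker inhibition. Compound 2 gives the lower of the two values, but compound 1 sits within the usual scatter of it, so the two compounds cannot be ordered on these data; neither can be called the more potent.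

The unmeasured compound 3, `NCc1occc1CN(Cc1nc2ccccc2[nH]1)C1CCCc2cccnc21`, is derived from compound 2 by a single change: a group of 8 heavy atoms (6 carbon, 1 nitrogen, 1 oxygen; one five-membered aromatic ring with 1 hetero atom) in place of a group of 7 heavy atoms (5 carbon, 1 nitrogen, 1 sulfur; one five-membered aromatic ring with 1 hetero atom), on an amine nitrogen. In words, a group of 8 heavy atoms (6 carbon, 1 nitrogen, 1 oxygen; one five-membered aromatic ring with 1 hetero atom) takes the place of a group of 7 heavy atoms (5 carbon, 1 nitrogen, 1 sulfur; one five-membered aromatic ring with 1 hetero atom), on an amine nitrogen whose other neighbours are a saturated chain carbon and a saturated ring carbon. Among the measured compounds shown here, no pair of measured compounds differs in this way, so there is no measured step to lean on.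

The expectation for compound 3 in this assay is therefore a step of a 1.7-fold higher number from compound 2 to compound 3 (0.23 log units; within the scatter), that is, no change beyond the scatter, with a slight lean toward a higher number. Compound 3 is estimated at 22 nM, with a range from 7 nM to 70 nM.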

Compound 3, half-maximal inhibitory concentration: 21 nM
Estimate against measurement, compound 3: 1.0-fold (0.02 log units) above; measured number inside the range.
By their numbers in this assay, from the lowest: compounds 2, 1 and 3 (each within the scatter of the next).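

In this assay, a group of 8 heavy atoms (6 carbon, 1 nitrogen, 1 oxygen; one five-membered aromatic ring with 1 hetero atom) in place of a group of 7 heavy atoms (5 carbon, 1 nitrogen, 1 sulfur; one five-membered aromatic ring with 1 hetero atom), on an amine nitrogen, gives a 1.6-fold higher number from compound 2 to compound 3 (0.21 log units; within the scatter). A group of 7 heavy atoms (5 carbon, 1 nitrogen, 1 oxygen; one five-membered aromatic ring with 1 hetero atom) in place of a group of 11 heavy atoms (one six-membered aromatic ring of carbon only), on a saturated chain carbon bound to an amine nitrogen, gives a 1.4-fold higher number from compound 1 to compound 3 (0.15 log units; within the scatter). Neither exchange separates the compounds, so across these three compounds an oxygen-containing five-membered ring gives a value that cannot be told apart from those of the sulfur-containing five-membered ring and the six-membered carbon ring.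

No measurement at hand speaks to why the three values lie together. The compounds shown leave open whether the nitrogen counted in these groups matters, which a hydroxyl or a carboxylic acid in place of the amine, or a longer chain carrying it, would address.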